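A few compounds are considered here, and "the series" means these few. Any claim that something is new, unique, unknown or untested is made for them only; others in the source may bear on it.

Three close relatives share one core, and they differ only in the group attached to the amine nitrogen in a ring. Compound 1 `CCCCNc1nc(N)nc2c1CN(S(C)(=O)=O)CC2` carries a methylsulfonyl there and gives 9.9 uM in an assay on HEK293 cells for agonist activity at Toll-like receptor 8 (Homo sapiens), read by a luciferase reporter, with a stated time of 6 h; on this read-out lower numbers stand for an effect already at smaller amounts and higher numbers for an effect only at larger amounts of compound. Compound 2 `CCCCNc1nc(N)nc2c1CN(Cc1ccccc1Cl)CC2` carries a 2-chlorobenzyl and gives 0.05 uM. Compound 3 `CCCCNc1nc(N)nc2c1CN(C(=O)C(C)C)CC2` carries an isopropylcarbonyl and gives 1.6 uM, which places compound 3 second highest of the three numbers: the step of a 6.2-fold lower number from compound 1 to compound 3 (0.79 log units; beyond the scatter) is beyond the scatter, as is the step of a 32-fold higher number from compound 2 to compound 3 (1.51 log units; beyond the scatter).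

Compound 4 `CCCCNc1nc(N)nc2c1CN(C(=O)c1ccncc1)CC2` keeps the carbonyl of compound 3 and changes what sits on it: pyridin-4-yl in place of isopropyl on a carbonyl carbon. Within the data shown here, no measured pair shows an alkyl replaced by an aromatic ring on a carbonyl carbon, so the two steps above bear on it only indirectly. Among the measured compounds shown here, they show that this nitrogen substituent can move the number a great deal in either direction, and the lowest number so far belongs to compound 2, which carries an aromatic ring on this nitrogen, though attached through a different link. A modest improvement is therefore expected, with wide uncertainty, so the step of a 2.0-fold lower number from compound 3 to compound 4 (0.30 log units; within the scatter) is the estimated outcome.

Compound 4 is expected to give about 0.8 uM in this assay, within 0.2 uM to 3 uM.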

Compound 4, minimum effective concentration: > 25 uM
Compound 4: no number, only a limit; the forecaster's own chance of this, stated with the estimate: 5%; at least 31-fold (1.49 log units) between middle value and limit.
By their numbers in this assay, from the lowest: compound 2; then compound 3; then compound 1. At a limit, above all of these: compound 4.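

Compound 4 gives no number here, only a limit of the read-out: the limit of > 25 uM in this assay, at which 1 of the 4 values shown sits. The carbonyl alone therefore does not set the result at this position, for keeping it and changing only what sits on it, pyridin-4-yl in place of isopropyl, gives an at least 15-fold higher number from compound 3 to compound 4 (1.19 log units; beyond the scatter). Nor does an aromatic ring on this part of the molecule ensure a low number: the 2-chlorobenzyl and the (pyridin-4-yl)carbonyl, both carrying one, are set apart by an at least 500-fold higher number from compound 2 to compound 4 (2.69 log units; beyond the scatter) read in the direction of the latter, and the (pyridin-4-yl)carbonyl also falls short of the methylsulfonyl, with an at least 2.5-fold higher number from compound 1 to compound 4 (0.40 log units; beyond the scatter).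

The compounds shown do not separate the effect of the aromatic ring on the carbonyl from that of the nitrogen within it, and a phenyl on the same carbonyl would tell these two apart. Also open, as far as these compounds go, is how much of the low number of compound 2 comes from its chlorine and how much from the link through a single carbon, which a plain benzyl or a 2-chlorobenzoyl on the ring nitrogen would address.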